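A few compounds are considered here, and "the series" means these few. Any claim that something is new, unique, unknown or untested is made for them only; others in the source may bear on it.

Measured compounds:
Compound 1 `COc1cc(-c2nn(-c3cccc(NC(=O)Nc4cc(C(F)(F)F)cc(C(F)(F)F)c4)c3)cc2-c2ccncc2)ccc1Cl` — 1120 nM
Compound 2 `COc1cc(-c2nn(-c3cccc(NC(=O)Nc4cccc(C(F)(F)F)c4)c3)cc2-c2ccncc2)ccc1Cl` — 1100 nM

Both compounds are read in a functional assay on OVCAR-4 cells (Homo sapiens) for inhibition, read by sulforhodamine B assay, with a stated time of 48 h; on this read-out higher numbers stand for weaker inhibition of growth and lower numbers for stronger inhibition of growth. Compound 1 gives 1120 nM and compound 2 gives 1100 nM; the step of a 1.0-fold lower number from compound 1 to compound 2 (0.01 log units; within the scatter) lies within the scatter, so on the two numbers available compound 2 cannot be set apart from compound 1.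

Compound 3 `COc1cc(-c2nn(-c3cccc(NC(=O)c4ccccc4)c3)cc2-c2ccncc2)ccc1Cl` is not yet measured. Relative to compound 2 the change is phenyl in place of (3-(trifluoromethyl)phenyl)amino on a carbonyl carbon. This removes both the amide-type nitrogen of the urea and the trifluoromethyl-bearing ring in one step, leaving a benzamide on the shared core.

Among the measured compounds shown here, only one measured step exists, and it bears on this change only in part: a 1.0-fold lower number from compound 1 to compound 2 (0.01 log units; within the scatter) shows that taking one trifluoromethyl off the terminal ring leaves the number unchanged. Nothing measured covers loss of the urea nitrogen itself. The expected step is therefore uncertain, with a modest move toward weaker inhibition the most plausible outcome, estimated as a 2.3-fold higher number from compound 2 to compound 3 (0.36 log units; beyond the scatter). Compound 3 is accordingly expected to give about 2500 nM in this assay, with a range from 700 nM to 9000 nM.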

Compound 3, concentration for 50% growth inhibition: 1170 nM
Compound 3: the middle estimate sits 2.1-fold (0.33 log units) above what was measured, and the stated range covers the measured number.
By their numbers in this assay, from the lowest: compounds 2, 1 and 3 (each within the scatter of the next).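

In this assay, the change to phenyl on the carbonyl carbon gives a 1.1-fold higher number from compound 2 to compound 3 (0.03 log units; within the scatter), so the number does not separate the two groups. The earlier step covered only the loss of one trifluoromethyl, whereas this one removes the whole (3-(trifluoromethyl)phenyl)amino group, including its nitrogen and hydrogen-bond donor, and puts phenyl, a group with fewer heavy atoms, in its place, still without a change beyond the scatter. At this position, then, neither the urea-type nitrogen nor the trifluoromethyl is needed to hold the number at this level, though no measurement on hand accounts for this.

From the compounds shown here alone, it remains open whether any group on this carbonyl carbon can move the number beyond the scatter in either direction, for example a methyl, a carboxylic acid or a longer chain ending in an amine. The shared core stays fixed across the compounds shown, so its contribution to the number is also unresolved.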